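The source may hold more compounds than are shown below. What is called first, only, known or untested is meant among the compounds shown, and "the series" means these compounds.

Of the compounds shown here, three of one family have been measured in a functional assay on HeLa cells (Homo sapiens) for cytotoxicity; a lower number here means a stronger inhibitor, a higher number a weaker inhibitor. Compound 1 `CCCCSC1=CC(=O)C(C[C@]2(C)[C@@H](C)CC[C@]3(C)C(C)=CCC[C@@H]23)=CC1=O` gives 25100 nM in this assay, the lowest of the three numbers. Compound 3 `CC1CCC[C@H]2[C@](C)(CC3=CC(=O)C(Cl)=CC3=O)[C@@H](C)CC[C@]12C` gives 34100 nM in this assay, a value that sits within the usual scatter of compound 1, so no order between the two can be claimed. Compound 2 `CC1=CCC[C@H]2[C@](C)(CC3=CC(=O)C=C(Sc4ccccc4)C3=O)[C@@H](C)CC[C@]12C` gives 54800 nM in this assay, which lies beyond the scatter from compound 1, so compound 2 is the weaker of that pair.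

The step now followed leads from compound 1 to compound 4 `CCCSC1=CC(=O)C(C[C@]2(C)[C@@H](C)CC[C@]3(C)C(C)=CCC[C@@H]23)=CC1=O`, which has not yet been measured in this assay. The change is small: hydrogen in place of methyl on a saturated chain carbon, three bonds along the chain from a sulfur. Within the data shown here, no measured pair shows what this kind of shortening of the chain does here, and nothing in the three values points in either direction. The expectation is therefore a step of no size beyond the scatter, a 1.1-fold higher number from compound 1 to compound 4 (0.03 log units; within the scatter). For compound 4 in this assay the estimate is 27000 nM, expected to fall between 11000 nM and 65000 nM.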

Compound 4, half-maximal inhibitory concentration: 97000 nM
For compound 4 the middle estimate is 3.6-fold (0.56 log units) below the measured one; measured number above the stated range.
By their numbers in this assay, from the lowest: compounds 1, 3, 2 and 4 (each within the scatter of the next, the first and the last beyond it).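

Replacing butyl with propyl, which puts hydrogen in place of methyl on a saturated chain carbon, three bonds along the chain from a sulfur, gives in this assay a 3.9-fold higher number from compound 1 to compound 4 (0.59 log units; beyond the scatter). Among these compounds, this is the first pair in the family that differs in one place only, and it shows that the end of this chain is not a silent position: losing one carbon, with no ring, hydrogen-bond donor, acceptor or charge involved, moves the number beyond the scatter. No measurement at hand explains why the number rises.

A single pair cannot show whether the number keeps rising as the chain shortens further to ethyl or methyl, or whether a longer chain such as pentyl would lower it. The compounds shown also leave open what a chain ending in an amine or a carboxylic acid would do at this place.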